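Sulfanyl chain variation on a shared core

This account rests on a few compounds, and the source may have more. Where it says the series, first, only, none or still open, it means among the compounds named here.

Compound 1 `COc1ccc(-n2c(SC)nnc2-c2cc(OC)c(OC)c(OC)c2)cc1`: in a functional assay on PC-3 cells (Homo sapiens) for inhibition, read by MTT assay, with a stated time of 48 h (a higher number here means a weaker inhibitor, a lower number a stronger inhibitor), compound 1 gives only a limit, > 60000 nM.
Compound 2 `CCSc1nnc(-c2cc(OC)c(OC)c(OC)c2)n1-c1ccc(OC)cc1`: in this assay compound 2 gives 57700 nM.
Compound 3 `COc1ccc(-n2c(SCc3ccccc3)nnc2-c2cc(OC)c(OC)c(OC)c2)cc1`: in this assay compound 3 gives 34100 nM.

Where compound 2 stands: it cannot be told apart from compound 3, since a 1.7-fold lower number from compound 2 to compound 3 (0.23 log units; within the scatter); the value of compound 1 is a limit, (the limit of > 60000 nM in this assay, at which 1 of the 3 values shown sits). Compound 4 `COc1ccc(C(=O)CSc2nnc(-c3cc(OC)c(OC)c(OC)c3)n2-c2ccc(OC)cc2)cc1` differs from compound 2 at the same place: (4-methoxyphenyl)carbonyl in place of methyl on a saturated chain carbon bound to a sulfur. The steps bearing on this change are an at least 1.0-fold lower number from compound 1 to compound 2 (0.01 log units; that floor lies within the scatter) and a 1.7-fold lower number from compound 2 to compound 3 (0.23 log units; within the scatter), both small. The change in compound 4 is larger in extent than that in compound 3, so a modestly lower number is expected, with wide uncertainty. Compound 4 is thus expected to show a 1.9-fold lower number from compound 2 to compound 4 (0.28 log units; within the scatter). For compound 4 the estimate in this assay is 30000 nM, between 8000 nM and 80000 nM.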

Compound 4, half-maximal inhibitory concentration: > 60000 nM
Compound 4 gave a limit, no number; the forecaster's own chance of this, stated with the estimate: 20%; at least 2.0-fold (0.30 log units) between middle value and limit.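

Compound 4, which carries the largest group at this place, gives only a limit, as compound 1 does: the limit of > 60000 nM in this assay, at which 2 of the 4 values shown sit.

The steps read an at least 1.0-fold higher number from compound 2 to compound 4 (0.01 log units; that floor lies within the scatter) and an at least 1.7-fold higher number from compound 3 to compound 4 (0.24 log units; that floor lies within the scatter); both are floors, so a larger group on this saturated chain carbon bound to a sulfur does not by itself bring a lower number. The step between compound 1 and compound 4 cannot be read, as both values are limits.

Going by these compounds, how far compound 4 lies past its limit stays open. So does whether an amine or a carboxylic acid at this place would give a step beyond the scatter.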